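A few compounds are considered here, and "the series" means these few. Any claim that something is new, unique, unknown or untested is made for them only; others in the source may bear on it.

Three compounds share one core and differ only in the group on an aromatic carbon of the fused ring system. Compound 1 `CCc1nnc2c(C#N)c(N3CCC(c4ccccc4)CC3)ccn12` gives 247% in a functional assay on CHO cells for positive allosteric modulation of metabotropic glutamate receptor 2 (Homo sapiens), read by GTPgammaS binding, with a stated time of 30 min; a lower number here means a smaller maximal response, a higher number a larger maximal response; compound 2 `N#Cc1c(N2CCC(c3ccccc3)CC2)ccn2c(CC3CC3)nnc12` gives 278%; compound 3 `CC(C)(C)c1nnc2c(C#N)c(N3CCC(c4ccccc4)CC3)ccn12` gives 207%, the lowest of the three numbers. The next compound, compound 4 `COCc1nnc2c(C#N)c(N3CCC(c4ccccc4)CC3)ccn12`, carries methoxymethyl in place of tert-butyl on an aromatic carbon. Every measured step concerns this same position: a number 31 percentage points higher from compound 1 to compound 2 (beyond the scatter), a number 40 percentage points lower from compound 1 to compound 3 (beyond the scatter) and a number 71 percentage points lower from compound 2 to compound 3 (beyond the scatter), so each exchange of this group has shifted the maximal response by a large amount. Because compound 3 sits lowest at 207% and the unbranched chains of compounds 1 and 2 gave higher numbers, compound 4 is expected to rise, with a number 28 percentage points higher from compound 3 to compound 4 (beyond the scatter) as the estimated step. Compound 4 is estimated at 235%, between 185% and 285%.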

Compound 4, largest response reached (Emax), in percent of the reference or control that the assay uses: 196%
For compound 4 the middle estimate is 39 percentage points above the measured one; the measured number falls inside the stated range.
By their numbers in this assay, from the lowest: compound 4; then compound 3; then compound 1; then compound 2.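

The exchange to methoxymethyl gives a number 11 percentage points lower from compound 3 to compound 4 (beyond the scatter) together with a number 51 percentage points lower from compound 1 to compound 4 (beyond the scatter) and a number 82 percentage points lower from compound 2 to compound 4 (beyond the scatter) in the maximal response, so compound 4 is the lowest of the four. Leaving tert-butyl therefore does not always raise the number at this carbon: compound 1 and compound 2 stand above compound 3, while compound 4 stands below it. Nothing measured here explains this drop.

Going by these compounds, whether an amine or a carboxylic acid on this carbon would give a number above or below that of compound 4 stays open. A propyl chain, with carbon in place of the oxygen of methoxymethyl, would help show whether the oxygen itself matters.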